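The compounds below may be only part of what the source reports. "The series", "measured", "known", "first", "only" and "open" are said of these compounds alone.

In a functional assay on KB-V1 cells (Homo sapiens) for cytotoxicity, read by MTT assay, with a stated time of 72 h (on this read-out higher numbers stand for weaker inhibition and lower numbers for stronger inhibition), compound 1 `O=C1Nc2ccccc2/C1=N/NC(=S)Nc1ccc(Cl)cc1` gives 4990 nM. Compound 2 `O=C1Nc2ccccc2/C1=N/NC(=S)Nc1ccc(C(=O)O)cc1` reaches only a limit of the assay, > 50000 nM. Its true value is therefore unknown, and it stands at the weak end of the numbers shown. Compound 3 `O=C1Nc2ccccc2/C1=N/NC(=S)Nc1ccc(C(F)(F)F)cc1` differs from it by trifluoromethyl in place of carboxy on an aromatic carbon, which puts trifluoromethyl in place of carboxy on an aromatic carbon, para to a large group. Going by the values given here, the one measured step that bears on this change is an at least 10-fold higher number from compound 1 to compound 2 (1.00 log units; beyond the scatter), where carboxy took the place of chloro at the same carbon. Removing the carboxy again is expected to bring a step of similar size in the opposite direction, towards lower numbers in this assay, although the limit on compound 2 leaves the exact size open. The step expected is an at least 10-fold lower number from compound 2 to compound 3 (1.00 log units; beyond the scatter). For compound 3 the estimate is 5000 nM, with an expected range of 1500 nM to 18000 nM.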

Compound 3, half-maximal inhibitory concentration: 2100 nM
For compound 3 the middle estimate is 2.4-fold (0.38 log units) above the measured one; the measured number falls inside the stated range.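

Going by these compounds alone, at this position, para to a large group, the earlier compounds set only chloro against carboxy in this assay and now a third group can be read. Trifluoromethyl in place of carboxy brings an at least 23-fold lower number from compound 2 to compound 3 (1.37 log units; beyond the scatter) and so the low numbers at this carbon do not belong to chloro alone, while trifluoromethyl in place of chloro brings a 2.4-fold lower number from compound 1 to compound 3 (0.38 log units; beyond the scatter) as a further, smaller gain beyond the scatter. Compound 2 remains a limit of the assay, so the larger step is only a bound: the limit of > 50000 nM in this assay, at which 1 of the 3 values shown sits.

On these data alone, whether an amine, a methoxy group or a plain hydrogen at this carbon would keep the lower numbers stays open. The compounds shown also leave open whether an ester or an amide here would stand nearer to compound 2 or to compound 3.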